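Nitro Substitution and Solubility on Two Related Cores

This account rests on a few compounds, and the source may have more. Where it says the series, first, only, none or still open, it means among the compounds named here.

Measured so far:
compound 1, `CCOCCCCc1cc(=O)c2ccccc2[nH]1`: > 200000 nM
compound 2, `CCOCCCCc1cc(=O)c2cc([N+](=O)[O-])ccc2[nH]1`: 50000 nM
compound 3, `CCCCCCCc1[nH]c2ccccc2c(=O)c1C(N)=O`: 5000 nM

In a physicochemical assay for solubility, read by HPLC, at pH 7.4 (a lower number here means a less soluble compound, a higher number a more soluble compound), compound 1 gives only (the limit of > 200000 nM in this assay, at which 1 of the 3 values shown sits), which is a limit of the method and not a number. Compound 2 differs from compound 1 by nitro in place of hydrogen on an aromatic carbon, and this produced an at least 4.0-fold lower number from compound 1 to compound 2 (0.60 log units; beyond the scatter). Compound 3 stands on another core; how the two cores differ is not broken down here. In this assay compound 3 shows the lowest number of the two that are numbers. Compound 4, `CCCCCCCc1[nH]c2ccc([N+](=O)[O-])cc2c(=O)c1C(N)=O`, has not yet been measured; it differs from compound 3 by nitro in place of hydrogen on an aromatic carbon, the same change as that from compound 1 to compound 2. Resting on an at least 4.0-fold lower number from compound 1 to compound 2 (0.60 log units; beyond the scatter), a step of comparable size, a 5.0-fold lower number from compound 3 to compound 4 (0.70 log units; beyond the scatter), is expected. Compound 4 is therefore estimated at 1000 nM.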

Compound 4, solubility: 15000 nM
Beside the measured number, compound 4's estimate is 15-fold (1.18 log units) below it; measured number outside the range, above it.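

In this assay, nitro in place of hydrogen on an aromatic carbon gives a 3.0-fold higher number from compound 3 to compound 4 (0.48 log units; beyond the scatter), whereas the same change on the core of compound 1 gives an at least 4.0-fold lower number from compound 1 to compound 2 (0.60 log units; beyond the scatter). The direction of this step therefore did not carry from one core to the other in these two pairs, but two pairs do not show what sets that direction. The step from compound 1 has no exact size, as compound 1 gives a limit and not a number: the limit of > 200000 nM in this assay, at which 1 of the 4 values shown sits.

From the compounds shown here alone, it remains open whether the opposite direction goes with the amide on the core of compound 3 or with its chain. Going by these compounds, it also remains open whether an amine or a carboxylic acid in place of nitro would step the same way on both cores.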